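The compounds below may be only part of what the source reports. "The series", "measured", "known", "first", "only" and "open" are said of these compounds alone.

Working notes on one series with a shared core, varied only at the aryl group on an aromatic nitrogen. In a functional assay on HCT-116 cells (Homo sapiens) for antiproliferative activity, read by MTT assay, with a stated time of 48 h (a lower number here means a stronger inhibitor, a higher number a weaker inhibitor), compound 1 `N#CC1=C(N)Oc2c(N)cc3nc4ccccc4nc3c2C12C(=O)N(Cc1cnnn1-c1ccc(F)cc1)c1ccccc12` returns only a limit, > 50000 nM. Compound 2 `CCc1cccc(C)c1-n1nncc1CN1C(=O)C2(C(C#N)=C(N)Oc3c(N)cc4nc5ccccc5nc4c32)c2ccccc21` likewise gives a limit in this assay, > 50000 nM. Compound 3 `Cc1ccc(C)c(-n2nncc2CN2C(=O)C3(C(C#N)=C(N)Oc4c(N)cc5nc6ccccc6nc5c43)c3ccccc32)c1` also sits at a limit in this assay, > 50000 nM. The steps a step that the two limits leave unreadable from compound 1 to compound 2, a step that the two limits leave unreadable from compound 1 to compound 3 and a step that the two limits leave unreadable from compound 2 to compound 3 cannot be read because of the limit of > 50000 nM in this assay, at which 3 of the 3 values shown sit. Compound 3 therefore stands with the other two at the limit and nowhere else on the numbers shown. Compound 4 `Cc1ccc(Cl)cc1-n1nncc1CN1C(=O)C2(C(C#N)=C(N)Oc3c(N)cc4nc5ccccc5nc4c32)c2ccccc21` carries chloro in place of methyl on an aromatic carbon. For the measured compounds named here, no measured step bears readably on this change, so the expected step that the limit leaves unreadable from compound 3 to compound 4 is set at none beyond the scatter. Compound 4 is accordingly expected near 60000 nM, from 20000 nM to 200000 nM, most probably once more as a limit.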

Compound 4, half-maximal inhibitory concentration: 37200 nM
Compound 4: middle estimate off by 1.6-fold (0.21 log units), on the high side, within the range that was stated.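

In this assay, for the compounds shown here, compound 4, with chloro on the aromatic carbon para to a methyl group, gives 37200 nM, the only value shown that is not a limit. This position can therefore return a readable number, with an at least 1.3-fold lower number from compound 3 to compound 4 (0.12 log units; that floor lies within the scatter), alongside an at least 1.3-fold lower number from compound 2 to compound 4 (0.12 log units; that floor lies within the scatter) and an at least 1.3-fold lower number from compound 1 to compound 4 (0.12 log units; that floor lies within the scatter). No step shown is established as beyond the scatter.

As far as these compounds go, the steps among compound 1, compound 2 and compound 3 cannot be read, and the true sizes of all steps stay open because of this bound: the limit of > 50000 nM in this assay, at which 3 of the 4 values shown sit. Whether an amine or a carboxylic acid in place of the chloro would also give a number remains open.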